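The source may hold more compounds than are shown below. What is called first, only, known or untested is meant among the compounds shown, and "the series" means these compounds.

In a functional assay on HT-29 cells (Homo sapiens) for cytotoxicity, read by XTT assay, with a stated time of 72 h (a higher number here means a weaker inhibitor, a lower number a stronger inhibitor), compound 1 `CCCCCCCC/C=C\CCCCCCCCOc1cc(O)c(C(C)=O)c(O)c1` gives 31000 nM. Compound 2 `C=C1CC[C@H]2C(C)(C)CCC[C@]2(C)[C@H]1CC/C(C)=C/Cc1c(O)cc(O)c2c(=O)c(O)c(-c3ccc(O)cc3)oc12` gives 29000 nM, and these two values lie within the usual scatter of each other. For compound 3 `C=C1CC[C@H]2C(C)(C)CCC[C@]2(C)[C@H]1CC/C(C)=C/COc1cc(O)c2c(=O)c(OC/C=C(\C)CC[C@H]3C(=C)CC[C@H]4C(C)(C)CCC[C@]34C)c(-c3ccc(OC)cc3)oc2c1` the assay reports only a limit, > 100000 nM. Compound 4 `CCCCCCCCCCCCCCCCCCOc1cc(O)c(C(C)=O)c(O)c1` has not yet been measured. It carries decyl in place of dec-1-en-1-yl on a saturated chain carbon, eight bonds along the chain from an oxygen on an aromatic ring. Within the data shown here, no measured pair of compounds shows a change of this kind, so no step beyond the scatter is expected in this assay, in either direction. The expected change is a 1.1-fold higher number from compound 1 to compound 4 (0.05 log units; within the scatter). The estimated value for compound 4 is 35000 nM, with an expected range from 14000 nM to 90000 nM.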

Compound 4, half-maximal inhibitory concentration: > 100000 nM
Compound 4 was reported as a limit; the forecaster's own chance of this, stated with the estimate: 20%; middle value at least 2.8-fold (0.45 log units) from the limit.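

Decyl in place of dec-1-en-1-yl, on a saturated chain carbon, eight bonds along the chain from an oxygen on an aromatic ring, gives an at least 3.2-fold higher number from compound 1 to compound 4 (0.50 log units; beyond the scatter) in this assay and is the first single change that can be read here. Among these compounds, the chain at this position is thus not indifferent to losing its one double bond, which no earlier pair could show. Compound 4 stands only at a limit, so the true size of the step stays unknown: the limit of > 100000 nM in this assay, at which 2 of the 4 values shown sit.

The compounds shown leave open whether a shorter chain, or a chain carrying an amine in this place, would keep the activity of compound 1.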